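This account rests on a few compounds, and the source may have more. Where it says the series, first, only, none or still open, it means among the compounds named here.

Measured so far:
- compound 1, `COc1ccc(C(=O)Nc2cccc(-c3ccnc4c(N)cccc34)c2)cc1OC`: 9500 nM
- compound 2, `Cc1cc(C(=O)Nc2cccc(-c3ccnc4c(N)cccc34)c2)c(C)o1`: a limit, > 20000 nM
- compound 3, `COc1ccc(C(=O)Nc2cccc(-c3ccnc4c(NC(C)=O)cccc34)c2)cc1OC`: 5300 nM

In a functional assay on A375P cells (Homo sapiens) for antiproliferative activity, read by MTT assay, with a stated time of 48 h (a higher number here means a weaker inhibitor, a lower number a stronger inhibitor), compound 3 gives the lowest of the two numbers shown, but the nearest value, that of compound 1, lies within the scatter (a 1.8-fold lower number from compound 1 to compound 3 (0.25 log units; within the scatter)), so no order between them is claimed. The value of compound 2 is only a limit of this assay (the limit of > 20000 nM in this assay, at which 1 of the 3 values shown sits).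

Compound 4, `CC(=O)Nc1cccc2c(-c3cccc(NC(=O)c4ccc5c(c4)OCCO5)c3)ccnc12`, is not yet measured. It differs from compound 3 by 2,3-dihydro-1,4-benzodioxin-6-yl in place of 3,4-dimethoxyphenyl on a carbonyl carbon. Going by the values given here, the only measured step at the same place is an at least 2.1-fold higher number from compound 1 to compound 2 (0.32 log units; beyond the scatter), where a 2,5-dimethylfuran-3-yl came in. Among the compounds with values here, compound 4 instead keeps the two oxygen acceptors on a six-membered aromatic ring of carbon only, now held in a six-membered non-aromatic ring with 2 hetero atoms, so that step is weak guidance; no measured step bears on this change directly. The expected step is therefore small, a 1.0-fold higher number from compound 3 to compound 4 (0.02 log units; within the scatter), not clearly beyond the scatter. Compound 4 is estimated at 5500 nM, with a range from 2000 nM to 16000 nM.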

Compound 4, half-maximal inhibitory concentration: 570 nM
For compound 4 the middle estimate is 9.6-fold (0.98 log units) above the measured one, and the stated range ends above it.
By their numbers in this assay, from the lowest: compound 4; then compounds 3 and 1 (each within the scatter of the next). At a limit, above all of these: compound 2.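

In this assay, going by these compounds alone, the change from 3,4-dimethoxyphenyl to 2,3-dihydro-1,4-benzodioxin-6-yl on the carbonyl carbon gives a 9.3-fold lower number from compound 3 to compound 4 (0.97 log units; beyond the scatter), the first step beyond the scatter towards a lower number. The heavy-atom count, oxygen count and hydrogen-bond acceptor count stay the same, so this place responds to holding the two oxygens in a six-membered non-aromatic ring, whereas the earlier step here, to 2,5-dimethylfuran-3-yl, had replaced the six-membered aromatic ring and gave a higher number. The compounds shown give no cause for this step.

On these data alone, it remains open whether the step carries over to the core with hydrogen in place of acetyl on the nitrogen. Also open, as far as these compounds go, is whether an amine or a longer chain on the non-aromatic ring keeps the low number of compound 4.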